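The source may hold more compounds than are shown below. What is called first, only, known or untested is meant among the compounds shown, and "the series" means these compounds.

Among the measured compounds shown here, in a functional assay on PANC-1 cells (Homo sapiens) for antiproliferative activity, read by fluorescence and resazurin assay, with a stated time of 48 h (a lower number here means a stronger inhibitor, a higher number a weaker inhibitor), compound 1 `O=C(N/N=C/c1ccncc1)c1cc2cc(Br)ccc2oc1=O` gives 25700 nM, the highest of the three numbers measured so far. Compound 2 `Cc1noc(NS(=O)(=O)c2ccc(NC(=O)c3cc4cc([N+](=O)[O-])ccc4oc3=O)cc2)c1C` gives 11900 nM and compound 3 `CCOc1ccc(NC(=O)c2cc3cc([N+](=O)[O-])ccc3oc2=O)cc1` gives 12100 nM, and each of these lies below the number for compound 1 by more than the usual scatter. Compound 4 `O=C(N/N=C/c1ccncc1)c1cc2ccccc2oc1=O` has not yet been measured. It differs from compound 1 in one place, with hydrogen in place of bromo on an aromatic carbon. For the measured compounds named here, only one measured step connects two compounds that differ in one place, a 1.0-fold higher number from compound 2 to compound 3 (0.01 log units; within the scatter), and it stays within the scatter. Going by the values given here, that step swaps other groups, so it bears on this change only loosely, and no measured pair shows what removing bromo does. The data therefore give no firm direction for a change in this assay. The expected step, a 1.1-fold higher number from compound 1 to compound 4 (0.04 log units; within the scatter), is no larger than the scatter. For compound 4 the estimated value is 28000 nM, with an expected range from 12000 nM to 65000 nM.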

Compound 4, half-maximal inhibitory concentration: 9750 nM
Compound 4: middle estimate off by 2.9-fold (0.46 log units), on the high side; the whole stated range lies above it.
By their numbers in this assay, from the lowest: compounds 4, 2 and 3 (each within the scatter of the next); then compound 1.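

In this assay, among the compounds shown here, this is the first measured pair that isolates the bromo on the aromatic carbon, and replacing it with hydrogen gives a 2.6-fold lower number from compound 1 to compound 4 (0.42 log units; beyond the scatter). With the rest of compound 1 unchanged, the bromo is therefore not needed for this antiproliferative activity, and the compound carrying hydrogen at this position is the modestly stronger inhibitor. Nothing available explains why the number falls with this change.

The compounds shown leave open whether another group on this carbon, such as chloro, methoxy or an amine, would give a number closer to that of compound 4 or of compound 1. They also leave open whether removing bromo has the same effect with a different side chain, as compound 2 and compound 3 differ from compound 1 in more than one place.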